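Compound 3 and a pyrazine exchange on the carbonyl carbon

This account rests on a few compounds, and the source may have more. Where it says the series, first, only, none or still open, it means among the compounds named here.

In an ADME assay on LLC-PK1 cells (Sus scrofa) for permeability (on this read-out lower numbers stand for lower permeability and higher numbers for higher permeability), compound 1 (`CNC(=O)[C@]12C[C@H]1[C@@](C)(c1cc(NC(=O)c3ccc(Cl)cn3)cc(F)c1F)N=C(N)S2`) gives 29 10^-6 cm/s as its number. Compound 2 (`CN(C)C(=O)[C@]12C[C@H]1[C@@](C)(c1cc(NC(=O)c3ccc(Cl)cn3)cc(F)c1F)N=C(N)S2`) gives 40 10^-6 cm/s in the same measurement, and compound 3 (`C#CCOc1cnc(C(=O)Nc2cc(F)c(F)c([C@@]3(C)N=C(N)S[C@@]4(COC)C[C@H]43)c2)c(C)c1`) gives 19 10^-6 cm/s there. Compound 3 thus stands within the scatter of compound 1 and beyond the scatter of compound 2, with the smaller number of that second pair.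

Compound 4 (`CCCOc1cnc(C(=O)Nc2cc(F)c(F)c([C@@]3(C)N=C(N)S[C@@]4(COC)C[C@H]43)c2)cn1`) has no number yet. It differs from compound 3 on a carbonyl carbon, with 5-propoxypyrazin-2-yl in place of 3-methyl-5-(propargyloxy)pyridin-2-yl (5-propoxypyrazin-2-yl in place of 3-methyl-5-(propargyloxy)pyridin-2-yl on a carbonyl carbon). Within the data shown here, the one measured step is a 1.4-fold higher number from compound 1 to compound 2 (0.14 log units; within the scatter) for methyl in place of hydrogen on an amide-type nitrogen, and it lies within the scatter. That step concerns another place in the structure, so it bears on this exchange only loosely. Among the measured compounds shown here, no measured pair makes this exchange, and the data give no direction for it. A shift beyond the scatter is therefore not expected in this assay. The expected step is a 1.1-fold higher number from compound 3 to compound 4 (0.04 log units; within the scatter) and it would remain within the scatter. The estimate for compound 4 is 21 10^-6 cm/s in an expected range of 11 10^-6 cm/s to 38 10^-6 cm/s for the coming measurement.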

Compound 4, apparent permeability: 18 10^-6 cm/s
The estimate for compound 4 lay 1.2-fold (0.07 log units) above the measured number; low and high end bracket the measured number.
By their numbers in this assay, from the lowest: compounds 4, 3, 1 and 2 (each within the scatter of the next, the first and the last beyond it).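

In this assay, among these compounds, the exchange of 3-methyl-5-(propargyloxy)pyridin-2-yl for 5-propoxypyrazin-2-yl on a carbonyl carbon whose other neighbour is an amide-type nitrogen gives a 1.1-fold lower number from compound 3 to compound 4 (0.02 log units; within the scatter) and thus shows that, for this pair, replacing the whole group at this position brings no shift beyond the scatter, something the earlier compounds, with their single step at another place, could not show. The exchange is a broad one in structure: one six-membered aromatic ring with 1 hetero atom gives way to one with 2 hetero atoms, the triple bond outside aromatic rings is lost, and the hydrogen-bond acceptors go from 2 to 3, yet the two numbers stay within the scatter of each other. No evidence at hand accounts for this result.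

Among the compounds shown here, the one step carries all these structural differences together, and what each contributes on its own stays open. On these data alone, it also remains open whether a longer alkoxy chain than propoxy, or an amine or a carboxylic acid on the ring at this position, would leave the number within the scatter as well.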